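Methoxyphenyl for naphthyl on the piperidine benzyl arm

A few compounds are considered here, and "the series" means these few. Any claim that something is new, unique, unknown or untested is made for them only; others in the source may bear on it.

Two compounds of the series have numbers in an in vitro functional assay on RBL cells for antagonist activity at C-C chemokine receptor type 8 (Homo sapiens), read by FLIPR and calcium flux (a higher number here means a weaker inhibitor, a lower number a stronger inhibitor), so far. Compound 1, `COc1ccc2nccc(C3CN(CCCNCc4cc5ccccc5[nH]4)C(=O)O3)c2c1`, gives 1580 nM in this assay. Compound 2, `COc1ccc2nccc(C3CN(C4CCN(Cc5ccc6ccccc6c5)CC4)C(=O)O3)c2c1`, gives 1260 nM in this assay; its number is the lower of the two, but the gap to compound 1 lies within the scatter, so the two cannot be ordered on what is in hand.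

Compound 3, `COc1ccc(CN2CCC(N3CC(c4ccnc5ccc(OC)cc45)OC3=O)CC2)cc1`, is the next step from compound 2. The change is 4-methoxyphenyl in place of naphthalen-2-yl on a saturated chain carbon bound to an amine nitrogen in a ring; cut one bond further out, it reads (naphthalen-2-yl)methyl to 4-methoxybenzyl. Within the data shown here, no pair of measured compounds differs in this way, so the step has no direct precedent. The two measured compounds, with their different amine arms, sit close together, which gives no sign that this arm carries much of the activity. The expectation is a step from compound 2 to compound 3 of a 1.7-fold higher number from compound 2 to compound 3 (0.24 log units; within the scatter), toward a somewhat higher number, of a size that may or may not exceed the scatter. Compound 3 is estimated at 2200 nM, with a range from 700 nM to 7000 nM.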

Compound 3, half-maximal inhibitory concentration: 1260 nM
Compound 3: middle estimate off by 1.7-fold (0.24 log units), on the high side, within the range that was stated.
By their numbers in this assay, from the lowest: compounds 2, 3 and 1 (each within the scatter of the next).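

In this assay, among these compounds, 4-methoxyphenyl in place of naphthalen-2-yl on a saturated chain carbon bound to an amine nitrogen in a ring gives no change at the digits printed from compound 2 to compound 3 (within the scatter), the first direct reading of a change at this place. The two six-membered aromatic rings of carbon only give way to one and a hydrogen-bond acceptor enters, yet this pair shows no difference that can be told from the scatter, so the second ring of naphthalen-2-yl is not required for a value in this range in this pair. No measured property of either group bears on this result.

Still open, as far as these compounds go, is whether a carboxylic acid or an amine on the phenyl ring, or a longer chain carrying the 4-methoxyphenyl, would read the same as compound 3 at this place. Also open, from the compounds shown here alone, is whether a saturated cyclohexyl ring would hold the value of compound 3 1260 nM, which would show whether an aromatic ring is needed here at all.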